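Swapping a Hydroxy for a Methyl on a Shared Scaffold

A few compounds are considered here, and "the series" means these few. Any claim that something is new, unique, unknown or untested is made for them only; others in the source may bear on it.

The measured compounds and their values:
compound 1, `Nc1ccc(CNc2cc(Br)cc3[nH]ncc23)cc1`, 24%
compound 2, `ONc1cccc(CNc2cc(Br)cc3[nH]ncc23)c1`, "not active" (no number reported)
compound 3, `Oc1ccc(CNc2cc(Br)cc3[nH]ncc23)cc1O`, "not active" (no number reported)

All three share the same core and differ only in the groups on the outer six-membered ring. In an assay for inhibition of Tryptophan 2,3-dioxygenase (Homo sapiens), with a stated time of 1 h, tested at 10 uM (a higher number here means more inhibition at the concentration tested (going by the name of the read-out), a lower number less inhibition), compound 1 reaches 24%, a modest effect at the single concentration tested. Compound 2 is reported as "not active" (no number reported) in this assay, with no number attached. Compound 3, which carries two hydroxy groups on that ring, likewise stands as "not active" (no number reported), so it has no number of its own and shares this position with compound 2; it sits at the bottom of what has been seen here.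

Compound 4, `Cc1cc(CNc2cc(Br)cc3[nH]ncc23)ccc1O`, is not yet measured. The change from compound 3 is methyl in place of hydroxy on an aromatic carbon. Going by the values given here, since compound 3 gives no number at all, there is no baseline against which a step can be sized, and the one compound with a number, compound 1, shows only a small effect. A small, scatter-level number is the most that seems plausible, and a result again reported as not active is quite likely.

Compound 4 is therefore expected to give about 10% in this assay, with a range from 0% to 25%.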

Compound 4, a percentage reported as inhibition, at one concentration (the size of the read-out at that concentration, not a potency): 30%
Beside the measured number, compound 4's estimate is 20 percentage points below it, outside the stated range (above it).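

Compound 3 has no number in this assay, so the change to methyl in place of hydroxy that gives compound 4 at 30% cannot be read as a step of any size. No available evidence bears on this result. Left open is how much that single change alters inhibition on the shared core.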